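Notes on a methylsulfonyl swap from compound 1

The source may report more compounds than this note shows. Statements on the series, on what has been measured and on what is new or still open speak of the compounds shown alone.

Values in a functional assay on Pfeiffer cells (Homo sapiens) for cytotoxicity, read by scintillation counting and thymidine incorporation, with a stated time of 4 days; a lower number here means a stronger inhibitor, a higher number a weaker inhibitor:
- compound 1 `COc1c([C@H](C)Nc2ncnc(N)c2C#N)cc(Cl)c(C)c1-c1ccc(C(=O)N(C)C)cn1`: 61 nM
- compound 2 `COc1c([C@H](C)n2nc(C)c3c(N)ncnc32)cc(Cl)c(C)c1C1CNC(=O)C1`: 480 nM

Compound 1 holds the lower of the two numbers, and its gap to compound 2 lies beyond the scatter. Compound 3 `COc1c([C@H](C)Nc2ncnc(N)c2C#N)cc(Cl)c(C)c1-c1cncc(S(C)(=O)=O)c1` keeps the core of compound 1 and carries 5-(methylsulfonyl)pyridin-3-yl in place of 5-(dimethylcarbamoyl)pyridin-2-yl on an aromatic carbon. Within the data shown here, no measured step covers this change. Starting from compound 1 at 61 nM, no step beyond the scatter is expected in this assay, in either direction. The expected step is a 1.1-fold higher number from compound 1 to compound 3 (0.06 log units; within the scatter). For compound 3 the estimated value is 70 nM, with an expected range from 22 nM to 220 nM.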

Compound 3, half-maximal inhibitory concentration: 17 nM
Compound 3: middle estimate off by 4.1-fold (0.61 log units), on the high side; the whole stated range lies above it.
By their numbers in this assay, from the lowest: compound 3; then compound 1; then compound 2.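

In this assay, the place ortho to a methoxy group and ortho to a methyl group on the core of compound 1 is sensitive to the choice of pyridine group: 5-(methylsulfonyl)pyridin-3-yl in place of 5-(dimethylcarbamoyl)pyridin-2-yl gives a step beyond the scatter (a 3.6-fold lower number from compound 1 to compound 3 (0.55 log units; beyond the scatter)). The dimethylcarbamoyl group is thus not required for activity at this level in this series. Nothing available explains this step.

The change alters the pyridine attachment and the substituent together, so their shares remain unresolved. A 5-(methylsulfonyl)pyridin-2-yl group would separate them.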